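A few compounds are considered here, and "the series" means these few. Any claim that something is new, unique, unknown or untested is made for them only; others in the source may bear on it.

The compounds share one core and differ in the group attached to it. Compound 1 `COc1ccc(-c2cc(NNC(=O)Nc3cc(Cl)nc(Cl)c3)nc3c2cnn3C)cc1` carries a phenyl bearing a methoxy group, and in an assay on isolated protein for binding affinity to sphingosine 1-phosphate receptor 2 (Homo sapiens), read by surface plasmon resonance (on this read-out higher numbers stand for weaker binding and lower numbers for tighter binding), compound 1 gives 520 nM. Compound 3 `Cn1ncc2c(-c3ccccc3)cc(NNC(=O)Nc3cc(Cl)nc(Cl)c3)nc21` has a bare phenyl instead; in this assay compound 3 gives 1020 nM, and the step of a 2.0-fold higher number from compound 1 to compound 3 (0.29 log units; within the scatter) lies within the scatter, so the two cannot be ordered. Compound 2 `CCCc1cc(NNC(=O)Nc2cc(Cl)nc(Cl)c2)nc2c1c(C)nn2C` carries a propyl together with an additional methyl on the core; in this assay compound 2 gives 2360 nM, a higher number than compound 3 shows and beyond the scatter. Compound 3 therefore stands second highest of the three numbers, closest to compound 1 and furthest from compound 2.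

Compound 4 `CCCc1cc(NNC(=O)Nc2cc(Cl)nc(Cl)c2)nc2c1cnn2C` differs from compound 3 by propyl in place of phenyl on an aromatic carbon. Within the data shown here, no measured step covers this exchange on its own; the only measured step, a 2.0-fold higher number from compound 1 to compound 3 (0.29 log units; within the scatter), concerns a substituent on the phenyl and is small. Among the measured compounds shown here, what bears on the change is that compound 2, the one propyl compound measured, gives 2360 nM, higher than compound 3. The step is thus expected to raise the number, a 1.9-fold higher number from compound 3 to compound 4 (0.27 log units; within the scatter). For compound 4 in this assay a value of about 1900 nM is estimated, within a range of 800 nM to 4500 nM.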

Compound 4, dissociation constant: 1400 nM
Compound 4: the middle estimate sits 1.4-fold (0.13 log units) above what was measured; the measured number falls inside the stated range.
By their numbers in this assay, from the lowest: compounds 1, 3, 4 and 2 (each within the scatter of the next, the first and the last beyond it).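

Propyl in place of phenyl on this aromatic carbon, opposite the ring nitrogen, gives a 1.4-fold higher number from compound 3 to compound 4 (0.14 log units; within the scatter) in this assay and so shows that this assay does not separate the open chain from the six-membered aromatic ring at this position. Among these compounds, only against the 4-methoxyphenyl of the earlier series does the same propyl give a step that can be read, a 2.7-fold higher number from compound 1 to compound 4 (0.43 log units; beyond the scatter) and thus a modest one, the first single exchange at this position to pass beyond the scatter. With propyl held in place, hydrogen in place of the additional methyl gives a 1.7-fold lower number from compound 2 to compound 4 (0.23 log units; within the scatter) and leaves that methyl on the core without a readable effect in this assay.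

Going by these compounds, whether a shorter chain such as ethyl, a longer chain such as pentyl, or an amine or a carboxylic acid on this carbon would part from propyl remains open. On these data alone, it is equally open whether a phenyl bearing fluorine or a hydroxyl group would follow the 4-methoxyphenyl or the bare phenyl.

Nothing in the data shown accounts for any of these steps.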